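The source may hold more compounds than are shown below. What is called first, only, known or untested is meant among the compounds shown, and "the series" means these compounds.

Measured in a functional assay on QG-56 cells (Homo sapiens) for cytotoxicity, read by MTT assay, with a stated time of 48 h; on this read-out higher numbers stand for weaker inhibition and lower numbers for stronger inhibition:
- compound 1 `COc1cc(/C=C/C(=O)C2=C(/C=C/c3ccc(O)c(OC)c3)NC(=O)NC2c2ccc(N(C)C)cc2)ccc1O`: 12500 nM
- compound 2 `COc1cc(/C=C/C(=O)C2=C(/C=C/c3ccc(O)c(OC)c3)NC(=S)NC2c2ccc(C)cc2)ccc1O`: 12500 nM

Compound 2, at 12500 nM, stands level with compound 1, at 12500 nM, within the scatter. The next compound, compound 3 `COc1cc(/C=C/C(=O)C2=C(/C=C/c3ccc(O)c(OC)c3)NC(=S)NC2c2ccccc2Cl)ccc1O`, has 2-chlorophenyl in place of 4-methylphenyl on a saturated ring carbon; the rest of compound 2 is kept. Going by the values given here, no measured pair differs in one place only, so the data offer no direct guide to this change. In this assay, no shift beyond the scatter is expected, and neither direction is favoured, with compound 2 at 12500 nM as the only anchor. The expected step is a 1.1-fold lower number from compound 2 to compound 3 (0.06 log units; within the scatter), within the scatter. Compound 3 is estimated at 11000 nM, with an expected range of 5000 nM to 25000 nM.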

Compound 3, half-maximal inhibitory concentration: 50000 nM
Compound 3: the middle estimate sits 4.5-fold (0.66 log units) below what was measured; measured number above the stated range.
By their numbers in this assay, from the lowest: compounds 1 and 2 (each within the scatter of the next); then compound 3.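

In this assay, going by these compounds alone, the group on the saturated ring carbon is not interchangeable: 2-chlorophenyl in place of 4-methylphenyl gives a 4.0-fold higher number from compound 2 to compound 3 (0.60 log units; beyond the scatter) and is the first single-place change that can be read. The heavy-atom count and the counted donors and acceptors of the two groups are the same, so those counts do not separate them, yet this position still responds to the swap, here towards weaker inhibition. Nothing measured in hand bears on the origin of this step.

The swap alters both the substituent and its place on the phenyl, so 2-methylphenyl and 4-chlorophenyl remain the open comparisons. Also open, on these data alone, is whether an amine on this phenyl, or unsubstituted phenyl itself, would stand closer to compound 2 or compound 3.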